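An Isoquinoline Isomer of a Quinoline Amide

This account rests on a few compounds, and the source may have more. Where it says the series, first, only, none or still open, it means among the compounds named here.

Compound 3 `CCCN(CC[C@H]1CC[C@H](NC(=O)c2ccc3ccccc3n2)CC1)[C@H]1CCc2nc(N)sc2C1` carries a quinolin-2-yl group on the carbonyl carbon of the shared core. In an assay on brain for displacement of a labelled ligand from D(3) dopamine receptor (Rattus norvegicus) (a higher number here means a weaker inhibitor, a lower number a stronger inhibitor), compound 3 gives 1.6 nM. Compound 1 `CCCN(CC[C@H]1CC[C@H](NC(=O)/C=C/c2ccc(F)cc2)CC1)[C@H]1CCc2nc(N)sc2C1` gives 1 nM, and compound 2 `CCCN(CC[C@H]1CC[C@H](NC(=O)/C=C/c2ccc(Cl)cc2)CC1)[C@H]1CCc2nc(N)sc2C1` gives 2.5 nM. The step of a 2.5-fold higher number from compound 1 to compound 2 (0.40 log units; beyond the scatter) is the only one beyond the scatter, while a 1.6-fold higher number from compound 1 to compound 3 (0.20 log units; within the scatter) and a 1.6-fold lower number from compound 2 to compound 3 (0.19 log units; within the scatter) both lie within it, so compound 3 stands second highest of the three numbers, separated from compound 1 and from compound 2 only within the scatter.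

Compound 4 `CCCN(CC[C@H]1CC[C@H](NC(=O)c2cccc3cnccc23)CC1)[C@H]1CCc2nc(N)sc2C1` differs from compound 3 by isoquinolin-5-yl in place of quinolin-2-yl on a carbonyl carbon. For the measured compounds named here, no measured pair tests a change of this kind, in which the same atoms are joined differently. The nearest guides are a 1.6-fold higher number from compound 1 to compound 3 (0.20 log units; within the scatter) and a 1.6-fold lower number from compound 2 to compound 3 (0.19 log units; within the scatter), where exchanging a 2-(4-fluorophenyl)ethenyl or 2-(4-chlorophenyl)ethenyl group for quinolin-2-yl moved the number only within the scatter, so quite different groups on that carbonyl carbon gave similar numbers. The estimated step of a 1.9-fold higher number from compound 3 to compound 4 (0.27 log units; within the scatter) is therefore expected to be small, near the edge of the scatter, with the number slightly higher. Compound 4 is estimated at 3 nM, within 1 nM to 12 nM.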

Compound 4, inhibition constant: 5.9 nM
Compound 4: the middle estimate sits 2.0-fold (0.29 log units) below what was measured, and the stated range covers the measured number.
By their numbers in this assay, from the lowest: compounds 1, 3 and 2 (each within the scatter of the next, the first and the last beyond it); then compound 4.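

In this assay, for the compounds shown here, this exchange gives the first step on this carbonyl carbon that lies beyond the scatter, a 3.7-fold higher number from compound 3 to compound 4 (0.57 log units; beyond the scatter), even though quinolin-2-yl and isoquinolin-5-yl have the same atoms and the same counts of rings, donors and acceptors. Compound 4 also separates from the two ethenyl amides, with a 2.4-fold higher number from compound 2 to compound 4 (0.37 log units; beyond the scatter) and a 5.9-fold higher number from compound 1 to compound 4 (0.77 log units; beyond the scatter), so the closeness of compound 1 and compound 3 and of compound 2 and compound 3 does not extend to isoquinolin-5-yl, and at this position the way the same atoms are joined can move the number. Nothing available here accounts for the difference between the two isomers.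

On these data alone, whether the higher number follows the place of the ring nitrogen or the point of attachment to the carbonyl carbon stays open, as the two change together in this pair. A quinolin-5-yl group on the same carbonyl carbon would separate these two changes.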